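From a Methyl Amide to a Pyridinylmethyl Amide

The compounds below may be only part of what the source reports. "The series", "measured", "known", "first", "only" and "open" are said of these compounds alone.

Within the data shown here, in an assay on isolated protein for inhibition of Gonadotropin-releasing hormone receptor (Rattus norvegicus) (on this read-out higher numbers stand for weaker inhibition and lower numbers for stronger inhibition), compound 2 `CCCn1c(SCc2cc([N+](=O)[O-])ccc2OC)nc2cc(NC(=O)NC(C)(C)C)cc(C(=O)NC)c21` gives 23 nM, the lowest of the two numbers known so far, while compound 1 `CCn1c(SCc2cc([N+](=O)[O-])ccc2OC)nc2cc(NC(=O)NC(C)(C)C)ccc21` gives 170 nM; these two compounds differ in more than one place, so their gap is only observed, not explained. Compound 3 `CCCn1c(SCc2cc([N+](=O)[O-])ccc2OC)nc2cc(NC(=O)NC(C)(C)C)cc(C(=O)NCc3cccnc3)c21` differs from compound 2 by a single change: pyridin-3-yl in place of hydrogen on a saturated chain carbon bound to an amide-type nitrogen. Among the measured compounds shown here, no measured pair isolates this change, so the expectation rests on compound 2 alone. A modest step is expected, a 1.5-fold lower number from compound 2 to compound 3 (0.19 log units; within the scatter), toward a lower number or none beyond the scatter. For compound 3 the estimate is 15 nM, with a range from 4 nM to 60 nM.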

Compound 3, half-maximal inhibitory concentration: 54 nM
The estimate for compound 3 lay 3.6-fold (0.56 log units) below the measured number, and the stated range covers the measured number.
By their numbers in this assay, from the lowest: compound 2; then compound 3; then compound 1.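

Compound 3 shows that this amide position can carry a whole pyridin-3-yl ring on the saturated chain carbon and still bind the receptor: in this assay, the change gives a 2.3-fold higher number from compound 2 to compound 3 (0.37 log units; beyond the scatter), a modest weakening rather than a collapse. The added ring therefore brings no gain here. Nothing available explains why the number rises. Going by these compounds, whether the ring nitrogen matters stays open, and a benzyl amide, with a plain phenyl ring, would test that. A pyridin-2-yl or pyridin-4-yl ring would show whether the nitrogen's placement counts.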